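Removing the Halogen from the Fused Ring of Compound 2

This account rests on a few compounds, and the source may have more. Where it says the series, first, only, none or still open, it means among the compounds named here.

Compound 2 `Cc1ccc2nc(/N=C3\C(=O)N(CN(c4ccccc4)c4ccccc4)c4cccc(Cl)c43)sc2c1` stands at the highest of the two numbers recorded so far, yet its nearest neighbour, compound 1 `Cc1ccc2nc(/N=C3\C(=O)N(CN(c4ccccc4)c4ccccc4)c4cccc(Br)c43)sc2c1`, sits within the scatter of it. In a functional assay on MDA-MB-468 cells (Homo sapiens) for cytotoxicity, read by sulforhodamine B assay, with a stated time of 48 h (on this read-out higher numbers stand for weaker inhibition of growth and lower numbers for stronger inhibition of growth), compound 1 gives 82300 nM, and in this assay compound 2 gives 85000 nM. Among the measured compounds shown here, the single step joining them, a 1.0-fold higher number from compound 1 to compound 2 (0.01 log units; within the scatter), is the only measured step, and it changes nothing beyond the scatter.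

Compound 3 `Cc1ccc2nc(/N=C3\C(=O)N(CN(c4ccccc4)c4ccccc4)c4ccccc43)sc2c1` carries the shared core of compound 2 with one alteration: hydrogen in place of chloro on an aromatic carbon. For the measured compounds named here, the only step that bears on this change is the one from compound 1 to compound 2, which also touched the same aromatic carbon and left the read-out essentially unmoved. With the halogen now absent rather than exchanged, the evidence gives no reason to expect a shift beyond the scatter in this assay, in either direction. Compound 3 is therefore expected to give 90000 nM, within a range from 40000 nM to 200000 nM, a step of a 1.1-fold higher number from compound 2 to compound 3 (0.02 log units; within the scatter) that is estimated to stay inside the usual scatter.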

Compound 3, concentration for 50% growth inhibition: 17700 nM
Estimate against measurement, compound 3: 5.1-fold (0.71 log units) above; measured number outside the range, below it.
By their numbers in this assay, from the lowest: compound 3; then compounds 1 and 2 (each within the scatter of the next).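

In this assay, the halogen on this aromatic carbon proves to matter even though exchanging one halogen for the other did not: a 4.8-fold lower number from compound 2 to compound 3 (0.68 log units; beyond the scatter) and a 4.6-fold lower number from compound 1 to compound 3 (0.67 log units; beyond the scatter) both lie beyond the scatter. Chloro and bromo thus stand within the scatter of each other, while hydrogen at the same place, on the six-membered aromatic ring of carbon only, gives stronger inhibition of growth, which makes compound 3 the most potent of the three in this read-out. Nothing available explains why losing the halogen moves the number in this direction.

The compounds shown leave open whether a fluoro group, a methoxy group or an amine on that carbon would fall with the two halogens or with hydrogen. They also leave open whether the same change would have a step of similar size in other cell lines, as all three numbers come from this assay alone.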